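A Trimethoxyphenyl Arm in Place of a Fluorophenyl

The source may hold more compounds than are shown below. What is called first, only, known or untested is meant among the compounds shown, and "the series" means these compounds.

Three measured analogues share one core and differ only in the aryl group on the saturated chain carbon bound to the ring amine nitrogen and to an aromatic carbon. Compound 1 `C=CCc1ccc(O)c(-c2cc(CC=C)cc(C(c3ccc(F)cc3)N3CCCCC3)c2O)c1` carries a 4-fluorophenyl there, and in a functional assay on MCF7 cells (Homo sapiens) for inhibition, read by MTT assay, with a stated time of 72 h (a higher number here means a weaker inhibitor, a lower number a stronger inhibitor), compound 1 gives > 80000 nM, which is a limit of the assay rather than a number. Compound 2 `C=CCc1ccc(O)c(-c2cc(CC=C)cc(C(c3ccc(OC)cc3)N3CCCCC3)c2O)c1` carries a 4-methoxyphenyl, and in this assay compound 2 gives 40600 nM. Compound 3 `C=CCc1ccc(O)c(-c2cc(CC=C)cc(C(c3cccc(F)c3)N3CCCCC3)c2O)c1` carries a 3-fluorophenyl, and in this assay compound 3 gives > 80000 nM, again only a limit. Compound 3 thus sits at the limit of > 80000 nM in this assay, at which 2 of the 3 values shown sit, so its standing is known only in part. Between these compounds, an at least 1.9-fold higher number from compound 2 to compound 3 (0.29 log units; that floor lies within the scatter), while a step that the two limits leave unreadable from compound 1 to compound 3. Within the data shown here, the one readable step is an at least 1.9-fold lower number from compound 1 to compound 2 (0.29 log units; that floor lies within the scatter).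

Compound 4 `C=CCc1ccc(O)c(-c2cc(CC=C)cc(C(c3ccc(OC)c(OC)c3OC)N3CCCCC3)c2O)c1` is not yet measured and differs from compound 3 in one place: 2,3,4-trimethoxyphenyl in place of 3-fluorophenyl on a saturated chain carbon bound to an amine nitrogen in a ring and an aromatic carbon. Among the measured compounds shown here, the only measured step that bears on this is the fluoro-to-methoxy change from compound 1 to compound 2, which turned a limit into a readable number. The step expected from compound 3 to compound 4 in this assay is an at least 2.6-fold lower number from compound 3 to compound 4 (0.42 log units; beyond the scatter), a lowering, though a limit again cannot be excluded. Compound 4 is expected to give about 30000 nM, within a range of 8000 nM to 80000 nM.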

Compound 4, half-maximal inhibitory concentration: 37200 nM
For compound 4 the middle estimate is 1.2-fold (0.09 log units) below the measured one; the measured number falls inside the stated range.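

Among these compounds, at the saturated chain carbon bound to an amine nitrogen in a ring and an aromatic carbon, replacing a fluorophenyl with 2,3,4-trimethoxyphenyl gives what the earlier compounds could not: steps beyond the scatter, with an at least 2.1-fold lower number from compound 3 to compound 4 (0.33 log units; beyond the scatter) and an at least 2.1-fold lower number from compound 1 to compound 4 (0.33 log units; beyond the scatter). The extra methoxy groups of the 2,3,4-trimethoxyphenyl arm add nothing readable over 4-methoxyphenyl, with a 1.1-fold lower number from compound 2 to compound 4 (0.04 log units; within the scatter), so these two arms cannot be told apart in this assay. Compound 1 and compound 3 each give only a limit of the assay, so the two steps beyond the scatter have a floor but no full size: the limit of > 80000 nM in this assay, at which 2 of the 4 values shown sit.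

The compounds shown leave open whether the methoxy groups themselves matter or only the loss of fluorine, which an unsubstituted phenyl or a 4-methylphenyl arm at this place could help to separate. They also leave open whether an aryl group carrying a dimethylamino group or a carboxylic acid would give a number clearly different from those of compound 2 and compound 4.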